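The source may hold more compounds than are shown below. What is called first, only, known or untested is meant among the compounds shown, and "the series" means these compounds.

Three compounds have been measured in an ADME assay on PC-3 cells (Homo sapiens) for cytotoxicity, read by WST assay, tested at 100 uM; a higher number here means more inhibition at the concentration tested (going by the name of the read-out), a lower number less inhibition:

compound 1 `C=CCOc1cccc(NC(=O)C2CCCN(C(=O)c3cc(C(F)(F)F)cc(C(F)(F)F)c3)C2)c1` gives 0%;
compound 2 `CCc1cccc(NC(=O)C2CCCN(C(=O)c3cc(C(F)(F)F)cc(C(F)(F)F)c3)C2)c1` gives 0%;
compound 3 `O=C(Nc1ccc(Cl)cc1)C1CCCN(C(=O)c2cc(C(F)(F)F)cc(C(F)(F)F)c2)C1` gives 14%.

Compound 3 stands highest of the three numbers. The step of a number 14 percentage points higher from compound 1 to compound 3 (beyond the scatter) and the step of a number 14 percentage points higher from compound 2 to compound 3 (beyond the scatter) both lie beyond the scatter, whereas the step of no change at the digits printed from compound 1 to compound 2 (within the scatter) shows nothing beyond the scatter, so the two compounds carrying a 3-(allyloxy)phenyl or a 3-ethylphenyl on the amide-type nitrogen sit together at the bottom and the 4-chlorophenyl compound alone sits higher.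

Compound 4 `COc1cccc(NC(=O)C2CCCN(C(=O)c3cc(C(F)(F)F)cc(C(F)(F)F)c3)C2)c1` has not yet been measured. It differs from compound 3 in one place: 3-methoxyphenyl in place of 4-chlorophenyl on an amide-type nitrogen. The two measured steps that bear on this change are the ones leading to compound 3, in which a 3-(allyloxy)phenyl or a 3-ethylphenyl was replaced by 4-chlorophenyl and the number rose modestly. Compound 4 moves in the opposite direction, from 4-chlorophenyl to 3-methoxyphenyl, a group that resembles those of compounds 1 and 2 more than it does the group of compound 3. The step to compound 4 is therefore expected to be a modest fall, roughly reversing those two steps, as the expected step of a number 12 percentage points lower from compound 3 to compound 4 (beyond the scatter) states. Compound 4 is estimated at 2% in this assay, with a range from 0% to 14%.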

Compound 4, a percentage reported as inhibition, at one concentration (the size of the read-out at that concentration, not a potency): 0%
Compound 4: middle estimate off by 2 percentage points, on the high side; measured number inside the range.
By their numbers in this assay, from the lowest: compounds 1, 2 and 4 (each within the scatter of the next); then compound 3.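

In this assay, the 3-methoxyphenyl group on the amide-type nitrogen falls in with the 3-(allyloxy)phenyl and 3-ethylphenyl groups, as a number 14 percentage points lower from compound 3 to compound 4 (beyond the scatter) shows, so the 4-chlorophenyl compound now stands apart from three different partners. Methoxy in place of ethyl on an aromatic carbon gives no change at the digits printed from compound 2 to compound 4 (within the scatter), and hydrogen in place of vinyl on a saturated chain carbon bound to an oxygen on an aromatic ring gives no change at the digits printed from compound 1 to compound 4 (within the scatter), so ethyl, methoxy and allyloxy on that aromatic carbon are not told apart by this read-out. Nothing measured here accounts for the separate position of the 4-chlorophenyl compound.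

The compounds leave open whether the higher number goes with the chlorine itself or with where the substituent stands, as the 4-chlorophenyl group differs from the other three groups in both, and a 3-chlorophenyl or a 4-methoxyphenyl group would separate the two. Also open, as far as these compounds go, is what an amine or a carboxylic acid on that aromatic ring would do to the number.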